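Swapping a Sulfur-Containing Ring for Piperidine

The compounds below may be only part of what the source reports. "The series", "measured", "known", "first", "only" and "open" are said of these compounds alone.

Three compounds share a core in which a pyridine-bearing amidine is linked through a thiosemicarbazide to a cyclic amine. In a functional assay on A-375 cells (Homo sapiens) for cytotoxicity, read by MTT assay, with a stated time of 72 h (on this read-out higher numbers stand for weaker inhibition and lower numbers for stronger inhibition), compound 1 `Cc1ccnc(/C(N)=N/NC(=S)N2CCSCC2)c1` gives 1200 nM. Compound 2 `Cc1ccnc(/C(N)=N/NC(=S)N2CCCC2)c1` gives 720 nM, and compound 3 `N/C(=N\NC(=S)N1CCSCC1)c1ccccn1` gives 760 nM. Compound 3 sits second highest of the three numbers, though all three lie within the scatter of one another. Compound 4 `N/C(=N\NC(=S)N1CCCCC1)c1ccccn1` differs from compound 3 by piperidin-1-yl in place of thiomorpholin-4-yl on a thiocarbonyl carbon. The closest measured step is a 1.7-fold lower number from compound 1 to compound 2 (0.22 log units; within the scatter), another ring swap at the same thiocarbonyl carbon, and a 1.6-fold lower number from compound 1 to compound 3 (0.20 log units; within the scatter) is likewise small. The step of a 1.3-fold lower number from compound 3 to compound 4 (0.10 log units; within the scatter) is therefore expected to stay within the scatter. Compound 4 is estimated at 600 nM, between 300 nM and 1300 nM.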

Compound 4, half-maximal inhibitory concentration: 680 nM
The estimate for compound 4 lay 1.1-fold (0.05 log units) below the measured number, and the stated range covers the measured number.
By their numbers in this assay, from the lowest: compounds 4, 2, 3 and 1 (each within the scatter of the next).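

Taking the ring sulfur out and leaving a six-membered ring with nitrogen as its only hetero atom gives a step within the scatter (a 1.1-fold lower number from compound 3 to compound 4 (0.05 log units; within the scatter)) in this assay. Together with the pyrrolidin-1-yl swap (a 1.7-fold lower number from compound 1 to compound 2 (0.22 log units; within the scatter)), this gives two ring changes on the thiocarbonyl carbon, each on a different core and neither beyond the scatter. No measurement here accounts for these small steps. Still open, as far as these compounds go, is whether morpholin-4-yl, 4-methylpiperazin-1-yl or an open-chain diethylamino group at this carbon would shift the number beyond the scatter.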